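The source may hold more compounds than are shown below. What is called first, only, known or untested is meant among the compounds shown, and "the series" means these compounds.

Measured so far:
compound 1 `O=C1C(=O)N(CCCCCn2cc(COc3cc(=O)oc4ccccc34)nn2)c2ccc(Br)cc21`: 43%
compound 2 `O=C1C(=O)N(CCCCn2cc(COc3cc(=O)oc4ccccc34)nn2)c2ccc([N+](=O)[O-])cc21`: 53%

In a functional assay on HCT-116 cells (Homo sapiens) for inhibition, read by sulforhodamine B assay, with a stated time of 48 h, tested at 50 uM (on this read-out lower numbers stand for less inhibition of growth and higher numbers for more inhibition of growth at the one concentration tested), compound 1 gives 43%, and compound 2 gives 53%; the two numbers lie within the usual scatter of each other, so neither can be set above or below the other. Compound 3 `O=C1C(=O)N(CCCCCn2cc(COc3cc(=O)oc4ccccc34)nn2)c2ccc(Cl)cc21` is not yet measured. It differs from compound 1 by chloro in place of bromo on an aromatic carbon. Among the compounds with values here, no step between two measured compounds is available to size this change against, so a step within the scatter is expected, with no direction favoured. For compound 3 in this assay the estimate is 41%, range 26% to 58%, meaning an expected step of a number 2 percentage points lower from compound 1 to compound 3 (within the scatter).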

Compound 3, percent growth inhibition at one concentration: 52%
Estimate against measurement, compound 3: 11 percentage points below; the measured number falls inside the stated range.
By their numbers in this assay, from the lowest: compounds 1, 3 and 2 (each within the scatter of the next).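

In this assay, within the data shown here, chloro in place of bromo on an aromatic carbon gives the first one-place step: a number 9 percentage points higher from compound 1 to compound 3 (within the scatter). At this position, one halogen can therefore stand in for the other without a readable change in growth inhibition at the one concentration tested. Nothing available explains this result or bears on it.

Still open, going by these compounds, is whether a group other than these two halogens, such as fluoro, methoxy or an amine, would move the number beyond the scatter at this carbon. Also open, on these data alone, is how a longer chain would read with chloro in place.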